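Chloropyridine in place of the methoxyphenylamino group: working notes

The source may hold more compounds than are shown below. What is called first, only, known or untested is meant among the compounds shown, and "the series" means these compounds.

Measured so far in an ADME assay on cells (Homo sapiens) for cytotoxicity, read by resazurin assay, with a stated time of 5 days (a lower number here means that less compound is tolerated, a higher number that more compound is tolerated), as half-maximal cytotoxic concentrations:
- compound 1 `COc1ccc(-c2nc(/C=C\c3cccc(Cl)c3)nc3ccsc23)cn1` gives 53000 nM in this assay
- compound 2 `COc1ccc(Nc2nc(CS(=O)(=O)c3cccc(Cl)c3)nc3ccsc23)cc1` gives 60000 nM in this assay
- compound 3 `COc1ccc(-c2nc(CSc3ccc(C(F)(F)F)cn3)nc3ccsc23)cn1` gives > 50000 nM as a limit and not a number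

Compound 2 and compound 1 lie within the scatter of each other, and no other number stands near them. Compound 4 `O=S(=O)(Cc1nc(-c2ccnc(Cl)c2)c2sccc2n1)c1cccc(Cl)c1` differs from compound 2 by 2-chloropyridin-4-yl in place of (4-methoxyphenyl)amino on an aromatic carbon with 2-chloropyridin-4-yl in place of (4-methoxyphenyl)amino on an aromatic carbon. Going by the values given here, no measured pair isolates this change. Compound 1 at 53000 nM and compound 2 at 60000 nM carry different groups at that carbon and still fall within the scatter of each other. Estimated here is a step of a 1.5-fold lower number from compound 2 to compound 4 (0.18 log units; within the scatter) in this assay with no change beyond the scatter expected. The expected value for compound 4 is 40000 nM with an estimated range of 15000 nM to 80000 nM in this series.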

Compound 4, half-maximal cytotoxic concentration: 63000 nM
Estimate against measurement, compound 4: 1.6-fold (0.20 log units) below, within the range that was stated.
By their numbers in this assay, from the lowest: compounds 1, 2 and 4 (each within the scatter of the next).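

In this assay, going by these compounds alone, this pair is the first to isolate the change at this aromatic carbon, and it reads a 1.1-fold higher number from compound 2 to compound 4 (0.02 log units; within the scatter). 2-Chloropyridin-4-yl and (4-methoxyphenyl)amino therefore cannot be told apart here, with the rest of the structure held constant. The exchange removes the carbon-only ring and the hydrogen-bond donor of the leaving group and brings in a ring nitrogen and a chlorine, yet the result stays within the scatter.

Within the data shown here, whether a primary amine or a carboxylic acid on this carbon would give a number apart from compound 2 remains open, as the single pair covers only these two groups. Compound 3 remains a limit and not a number, and it cannot be placed among the others: the limit of > 50000 nM in this assay, at which 1 of the 4 values shown sits.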